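Compound 1 to compound 4: carbonyl substituent swap

The compounds below may be only part of what the source reports. "The series", "measured", "known", "first", "only" and "open" are said of these compounds alone.

In an ADME assay on CCRF-CEM cells (Homo sapiens) for cytotoxicity, with a stated time of 4 days (on this read-out higher numbers stand for lower toxicity in this test and lower numbers for higher toxicity in this test), compound 1 `Cc1cn([C@@H]2O[C@H](CO[Si](C)(C)C(C)(C)C)[C@@]3(OS(=O)(=O)C=C3N)[C@H]2O[Si](C)(C)C(C)(C)C)c(=O)n(C(=O)OC(C)(C)C)c1=O` gives 26000 nM and holds the higher of the two actual numbers in the set. Compound 3 `Cc1cn([C@@H]2O[C@H](CO[Si](C)(C)C(C)(C)C)[C@@]3(OS(=O)(=O)C=C3N)[C@H]2O[Si](C)(C)C(C)(C)C)c(=O)n(C(=O)C2CC2)c1=O` lies nearest with 11000 nM as its value. Compound 2 `COC(=O)n1c(=O)c(C)cn([C@@H]2O[C@H](CO[Si](C)(C)C(C)(C)C)[C@@]3(OS(=O)(=O)C=C3N)[C@H]2O[Si](C)(C)C(C)(C)C)c1=O` reads > 100000 nM and this is a limit of the assay, not a number.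

Compound 4 `COC(=O)CCCC(=O)n1c(=O)c(C)cn([C@@H]2O[C@H](CO[Si](C)(C)C(C)(C)C)[C@@]3(OS(=O)(=O)C=C3N)[C@H]2O[Si](C)(C)C(C)(C)C)c1=O` is not yet measured. It carries 3-(methoxycarbonyl)propyl in place of tert-butoxy on a carbonyl carbon.

Two measured steps replace the same tert-butoxy group and point in opposite directions. With methoxy in its place the result is an at least 3.8-fold higher number from compound 1 to compound 2 (0.58 log units; beyond the scatter) and with cyclopropyl it is a 2.4-fold lower number from compound 1 to compound 3 (0.37 log units; beyond the scatter) as the change. Compound 4 carries neither group, so neither direction can be carried over with confidence, and its expected value stays within the span these steps mark out.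

The estimated step is a 1.1-fold higher number from compound 1 to compound 4 (0.03 log units; within the scatter) with no firm direction expected. For compound 4 the expected value is 28000 nM within an estimated range of 9000 nM to 90000 nM for now.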

Compound 4, half-maximal cytotoxic concentration: 9900 nM
Estimate against measurement, compound 4: 2.8-fold (0.45 log units) above; measured number inside the range.
By their numbers in this assay, from the lowest: compounds 4 and 3 (each within the scatter of the next); then compound 1. At a limit, above all of these: compound 2.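

The group 3-(methoxycarbonyl)propyl, which has no ring, gives a 2.6-fold lower number from compound 1 to compound 4 (0.42 log units; beyond the scatter) in this assay on a carbonyl carbon, so a lower number than that of compound 1 is not confined to the cyclopropyl ring of compound 3. Exchanging cyclopropyl for this chain gives a 1.1-fold lower number from compound 3 to compound 4 (0.05 log units; within the scatter) and leaves the two groups unresolved in this test. Methoxy goes against this shared direction, with an at least 10-fold lower number from compound 2 to compound 4 (1.00 log units; beyond the scatter) as the step, and compound 2 contributes a limit rather than a number: the limit of > 100000 nM in this assay, at which 1 of the 4 values shown sits.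

Going by these compounds, whether the terminal methyl ester of the chain contributes to the result stays open, since a carboxylic acid or an amine at the chain end would be needed to separate it from the chain itself. Also open, on these data alone, is where ethyl or a longer unbranched alkyl chain would fall between methoxy and 3-(methoxycarbonyl)propyl.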